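This account rests on a few compounds, and the source may have more. Where it says the series, first, only, none or still open, it means among the compounds named here.

Compound 3 `COc1ccc(OC)c(Nc2cc(NC(=O)Nc3c(Cl)cccc3Cl)ncn2)c1` holds the highest of the three numbers in a functional assay on HCC827 cells (Homo sapiens) for inhibition, read by MTT assay, with a stated time of 48 h, tested at 10 uM; on this read-out lower numbers stand for less inhibition and higher numbers for more inhibition at the one concentration tested (going by the name of the read-out): compound 3 reaches 94.1%, whereas compound 2 `COc1cc(NC(=O)Nc2cc(Nc3cc(Br)ccc3OC)ncn2)cc(OC)c1` gives 76.3% and compound 1 `COc1cc(NC(=O)Nc2cc(Nc3ccc(OC)c(C)c3)ncn2)cc(OC)c1` gives 48.3%. Within the data shown here, the only step between measured compounds, a number 28 percentage points higher from compound 1 to compound 2 (beyond the scatter), concerns an exchange of the whole aryl group on a nitrogen and does not bear on the change now considered. Compound 4 `COc1ccc(F)cc1Nc1cc(NC(=O)Nc2c(Cl)cccc2Cl)ncn1` differs from compound 3 in one place: fluoro in place of methoxy on an aromatic carbon. Among the measured compounds shown here, no measured pair tests this kind of change, so only a small shift is expected; for compound 4 the estimated step is a number 8.1 percentage points lower from compound 3 to compound 4 (within the scatter), within the scatter. Compound 4 is therefore expected to give 86% in this assay, with a range from 66% to 100%.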

Compound 4, a percentage reported as inhibition, at one concentration (the size of the read-out at that concentration, not a potency): 78%
Compound 4: middle estimate off by 8 percentage points, on the high side, within the range that was stated.
By their numbers in this assay, from the lowest: compound 1; then compounds 2 and 4 (each within the scatter of the next); then compound 3.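

With fluoro in place of methoxy on this aromatic carbon, para to a methoxy group, this assay gives a number 16.1 percentage points lower from compound 3 to compound 4 (beyond the scatter). Among these compounds, this is the only measured pair that tests a change at this position, and it shows that the read-out responds to this single exchange, with the methoxy compound giving the higher number. Nothing measured accounts for the step.

The compounds shown leave open whether other groups at this carbon, such as a hydroxy group, an amine or a longer alkoxy chain, would keep or lower the number.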